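A few compounds are considered here, and "the series" means these few. Any claim that something is new, unique, unknown or untested is made for them only; others in the source may bear on it.

Compound 1 `c1ccc(-c2cnoc2)cc1` gives > 25000 nM in an assay on isolated protein for inhibition of Tryptophan 2,3-dioxygenase (Homo sapiens), read by fluorescence and mass spectrometry, with stated times of 5 min and 15 min; on this read-out higher numbers stand for weaker inhibition and lower numbers for stronger inhibition.
Compound 2 `CNc1oncc1-c1ccccc1` gives 190 nM.
Compound 3 `NC(=O)c1oncc1-c1ccccc1` gives > 25000 nM.

The values of compound 1 and compound 3 are limits of the assay, not numbers. Compound 3 stands at the limit of > 25000 nM in this assay, at which 2 of the 3 values shown sit, whereas compound 2 gives a far lower number. Compound 4 `CNC(=O)c1oncc1-c1ccccc1` differs from compound 3 by methyl in place of hydrogen on an amide-type nitrogen. Among the measured compounds shown here, none of the measured steps alters an amide nitrogen in this way, so none bears on it directly. The nearest comparison is an at least 130-fold higher number from compound 2 to compound 3 (2.11 log units; beyond the scatter), which places the carbamoyl compound at the limit; compound 4 keeps that carbamoyl. Compound 4 is therefore expected to remain near the limit, with a number no higher from compound 3 to compound 4 (the limit leaves the size open) as the estimated step. The estimate for compound 4 is 25000 nM, within a range of 6000 nM to 100000 nM.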

Compound 4, half-maximal inhibitory concentration: > 25000 nM
Compound 4 ended at the assay's limit (the forecaster's own chance of this, stated with the estimate: 70%); the middle value sits exactly at the limit.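

In this assay compound 4 gives > 25000 nM, a limit of the assay and not a number. Adding methyl to the amide-type nitrogen therefore does not recover the strong inhibition of the methylamino compound: methylcarbamoyl in place of methylamino on an aromatic carbon gives an at least 130-fold higher number from compound 2 to compound 4 (2.11 log units; beyond the scatter). The steps to compound 4 from compound 1 and from compound 3 cannot be read, and only compound 2 stands clear of the limit: the limit of > 25000 nM in this assay, at which 3 of the 4 values shown sit.

Any effect of this methyl on the amide-type nitrogen stays hidden at the limit. As far as these compounds go, how ethylamino, dimethylamino or a carboxylic acid in place of methylamino would read remains open.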